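One Stereocentre Changed on Compound 3

A few compounds are considered here, and "the series" means these few. Any claim that something is new, unique, unknown or untested is made for them only; others in the source may bear on it.

Measured in a functional assay on cells (T-cell, Homo sapiens) for inhibition, read by scintillation counting and thymidine incorporation, with stated times of 60 min and 3 days; on this read-out lower numbers stand for stronger inhibition and higher numbers for weaker inhibition:
- compound 1 `COc1ccc(-c2cc3c(N[C@H](CO)CC(C)C)c(C(N)=O)cnn3c2)cn1`: 190 nM
- compound 2 `COc1ccc(-c2cc3c(N[C@H](CO)[C@@H](C)O)c(C(N)=O)cnn3c2)cn1`: 370 nM
- compound 3 `C[C@@H](O)[C@@H](CO)Nc1c(C(N)=O)cnn2cc(-c3ccccc3)cc12`: 70 nM

Compound 3, at 70 nM, has the lowest number of the three in this assay, and both other values lie beyond the scatter from it. The next compound examined is compound 4 `C[C@@H](O)[C@H](CO)Nc1c(C(N)=O)cnn2cc(-c3ccccc3)cc12`, and its relation to compound 3 is simple: the two compounds have the same atoms and bonds and differ only in configuration as drawn: 1 of 2 stereo elements differ; a stereocentre at a saturated chain carbon is drawn R in compound 3 and S in compound 4. Among the compounds with values here, no measured step tests a change of configuration, so the data offer only indirect guidance. Placing 1-hydroxyethyl where isobutyl stood gave a 1.9-fold higher number from compound 1 to compound 2 (0.29 log units; within the scatter). Placing phenyl where 6-methoxypyridin-3-yl stood gave a 5.3-fold lower number from compound 2 to compound 3 (0.72 log units; beyond the scatter). Neither step gauges the inversion, although they do show that this small series has so far moved by modest amounts. Compound 3 also sits at the low end of the series, which leaves more room for a rise than for a fall. A modest move towards weaker inhibition is therefore expected, comparable in size to the larger measured step, but with wide uncertainty. The expected change in this assay is a 5.0-fold higher number from compound 3 to compound 4 (0.70 log units; beyond the scatter). For compound 4 the estimated value is 350 nM, with an expected range from 100 nM to 1500 nM.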

Compound 4, half-maximal inhibitory concentration: 1800 nM
Compound 4: middle estimate off by 5.1-fold (0.71 log units), on the low side, outside the stated range (above it).
By their numbers in this assay, from the lowest: compound 3; then compounds 1 and 2 (each within the scatter of the next); then compound 4.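

In this assay, within the data shown here, inverting a single stereocentre at a saturated chain carbon gives a 26-fold higher number from compound 3 to compound 4 (1.41 log units; beyond the scatter), and this is the largest step so far. It exceeds both the replacement of the aromatic group, a 5.3-fold lower number from compound 2 to compound 3 (0.72 log units; beyond the scatter), and the replacement of isobutyl by 1-hydroxyethyl, a 1.9-fold higher number from compound 1 to compound 2 (0.29 log units; within the scatter), so the spatial arrangement at this carbon matters more here than either change of group did. The whole of the step can be assigned to that one inversion, because nothing else separates the pair: the fact that compounds 3 and 4 differ only in the configuration as drawn.

The compounds shown leave open whether the same inversion would cost as much with 6-methoxypyridin-3-yl in place of phenyl or with isobutyl in place of 1-hydroxyethyl, and what inverting the second stereocentre, alone or together with the first, would do. They also leave open how this read-out would respond if the chain carried an amine, a carboxylic acid or a longer chain in place of 1-hydroxyethyl, with either configuration at the carbon that separates compound 3 and compound 4.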